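Methoxy to methyl on the pendant aryl of compound 1

The source may hold more compounds than are shown below. What is called first, only, known or untested is meant among the compounds shown, and "the series" means these compounds.

Compound 1 `CC#CC(CC(=O)O)c1ccc(OCc2ccc3nc(-c4ccc(OC)cc4)cn3c2)cc1` carries a methoxy group on its outer phenyl ring. In an assay on isolated protein for agonist activity at Free fatty acid receptor 1 (Homo sapiens) (on this read-out higher numbers stand for an effect only at larger amounts of compound and lower numbers for an effect already at smaller amounts), compound 1 gives 47 nM, the lowest of the three numbers measured: compound 3 `CC#CC(CC(=O)O)c1ccc(OCc2ccn3cc(-c4ccc(F)cc4)nc3c2)cc1` gives 783 nM and compound 2 `CC#CC(CC(=O)O)c1ccc(OCc2ccn3cc(-c4cccc(C)c4)nc3c2)cc1` gives 1510 nM, both clearly beyond the scatter from compound 1. Within the data shown here, compounds 2 and 3 share a core that differs from that of compound 1, and the only step measured between them, a 1.9-fold lower number from compound 2 to compound 3 (0.29 log units; within the scatter), swaps one substituted phenyl for another within the scatter.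

Compound 4 `CC#CC(CC(=O)O)c1ccc(OCc2ccc3nc(-c4ccc(C)cc4)cn3c2)cc1` differs from compound 1 by methyl in place of methoxy on an aromatic carbon. Among the measured compounds shown here, no measured step addresses a change of methoxy to methyl, and the step from compound 2 to compound 3 concerns other groups on another core, so it bears only loosely on the case; it does suggest that small changes to this phenyl ring move the number little. The expectation for compound 4 is therefore a step of a 1.5-fold higher number from compound 1 to compound 4 (0.17 log units; within the scatter) in this assay, a shift that stays within the scatter. Compound 4 is estimated to give 70 nM, with a range from 25 nM to 200 nM.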

Compound 4, half-maximal effective concentration: 507 nM
Estimate against measurement, compound 4: 7.2-fold (0.86 log units) below; measured number above the stated range.
By their numbers in this assay, from the lowest: compound 1; then compounds 4, 3 and 2 (each within the scatter of the next, the first and the last beyond it).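

On the core of compound 1, the group para to a large group on the outer phenyl ring turns out to matter a great deal: in this assay, putting methyl in place of methoxy brings an 11-fold higher number from compound 1 to compound 4 (1.03 log units; beyond the scatter), a large step well beyond the scatter. Among these compounds, the only step available before this one, a 1.9-fold lower number from compound 2 to compound 3 (0.29 log units; within the scatter), lay within the scatter and concerned other groups on another core, so the earlier compounds gave no sign that one small substituent on this ring could move the number so far. The step shows that, between these two compounds, the 4-methoxyphenyl goes with an effect at much smaller amounts of compound than the 4-methylphenyl, but nothing given here accounts for the size of that difference.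

From the compounds shown here alone, whether the oxygen of the methoxy group or the group as a whole carries this difference stays open, and a hydroxy group, an ethoxy group or a chlorine atom at the same place would help to separate the two. Going by these compounds, it is also open whether the same change of methoxy to methyl would produce a step of similar size on the core shared by compound 2 and compound 3.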